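The compounds below may be only part of what the source reports. "The series", "measured", "known", "first", "only" and "open" are said of these compounds alone.

Working notes on the series. Compound 1 `O=c1cc(CNCc2ccccc2Cl)oc2ccc(O)c(O)c12` is the reference point. In an ADME assay on Huh-7 cells (Homo sapiens) for cytotoxicity (a lower number here means that less compound is tolerated, a higher number that more compound is tolerated), compound 1 gives > 100000 nM, which is a limit of the assay and not a number. Compound 2 `O=c1cc(CNCc2ccc(F)cc2)oc2ccc(O)c(O)c12` shares the core. In this assay compound 2 gives > 100000 nM, again a limit. Compound 3 `O=c1cc(CNCc2ccc(Cl)cc2)oc2ccc(O)c(O)c12` is the third member. In this assay compound 3 gives > 100000 nM, also a limit. The three measured steps, a step that the two limits leave unreadable from compound 1 to compound 2, a step that the two limits leave unreadable from compound 1 to compound 3 and a step that the two limits leave unreadable from compound 2 to compound 3, cannot be sized, because all three values sit at the limit of > 100000 nM in this assay, at which 3 of the 3 values shown sit.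

Compound 4 `O=c1cc(CNCc2ccc(I)cc2)oc2ccc(O)c(O)c12` is the compound not yet measured. Its change from compound 1 is 4-iodophenyl in place of 2-chlorophenyl on a saturated chain carbon bound to an amine nitrogen. Going by the values given here, the steps that bear on it are the two ring-substituent swaps already run, from compound 1 to compound 2 and from compound 1 to compound 3, and neither gave a readable size. Among the compounds with values here, no measured step in this assay points in either direction, so no step beyond the scatter is expected from compound 1 to compound 4; the estimated step is a step that the limit leaves unreadable from compound 1 to compound 4. Compound 4 is expected to give about 150000 nM, within a range from 60000 nM to 400000 nM, most likely again reported only as a limit.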

Compound 4, half-maximal cytotoxic concentration: 41700 nM
Compound 4: middle estimate off by 3.6-fold (0.56 log units), on the high side; the whole stated range lies above it.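

In this assay, going by these compounds alone, compound 4 is the first member of the series to give a number rather than a limit, at 41700 nM, so the group on the saturated chain carbon bound to an amine nitrogen can change this read-out, with an at least 2.3-fold lower number from compound 1 to compound 4 (0.37 log units; beyond the scatter). Within the data shown here, that step changes both the halogen and the group's name from 2-chlorophenyl to 4-iodophenyl, whereas the single swaps on the aromatic carbon isolate the halogen, giving an at least 2.3-fold lower number from compound 3 to compound 4 (0.37 log units; beyond the scatter) and an at least 2.3-fold lower number from compound 2 to compound 4 (0.37 log units; beyond the scatter). All three steps are minimum sizes, and the steps among compound 1, compound 2 and compound 3 cannot be read: the limit of > 100000 nM in this assay, at which 3 of the 4 values shown sit.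

The compounds shown leave open how far compound 1, compound 2 and compound 3 truly lie from compound 4, and whether iodo gives the same lower number as part of a 2-iodophenyl group. They also leave open whether a 4-bromophenyl or 4-methylphenyl group, or a longer chain between the amine nitrogen and the ring, would give a number or stay at the limit.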